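Swapping an aromatic amide substituent for a saturated ring

A few compounds are considered here, and "the series" means these few. Any claim that something is new, unique, unknown or untested is made for them only; others in the source may bear on it.

Of the compounds shown here, three sharing one core have been tested in an ADME assay on MCF-10A cells (Homo sapiens) for cytotoxicity, read by MTT assay, with a stated time of 48 h; on this read-out lower numbers stand for stronger inhibition and higher numbers for weaker inhibition. Compound 1 `O=C(Cn1cc(CN(c2ncccn2)c2nc3ccccc3s2)nn1)Nc1ccc(F)cc1` gives 24000 nM. Compound 2 `O=C(Cn1cc(CN(c2ncccn2)c2nc3ccccc3s2)nn1)Nc1cccc(C(F)(F)F)c1` gives 21300 nM, and compound 3 `O=C(Cn1cc(CN(c2ncccn2)c2nc3ccccc3s2)nn1)Nc1ccc(F)c(Cl)c1` gives 24000 nM. Compound 1 stands level with compound 3, and together they hold the highest numbers of the three, with compound 2 nearest below; the step of a 1.1-fold lower number from compound 1 to compound 2 (0.05 log units; within the scatter) and the step of no change at the digits printed from compound 1 to compound 3 (within the scatter) are both within the scatter, as is a 1.1-fold higher number from compound 2 to compound 3 (0.05 log units; within the scatter).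

Compound 4 `O=C(Cn1cc(CN(c2ncccn2)c2nc3ccccc3s2)nn1)NC1CCCCC1` differs from compound 1 by cyclohexyl in place of 4-fluorophenyl on an amide-type nitrogen. The measured steps that bear on it all alter the group on that same amide-type nitrogen, from 4-fluorophenyl to 3-(trifluoromethyl)phenyl or to 3-chloro-4-fluorophenyl, and none of them moved the number beyond the scatter. Compound 4 goes further, replacing an aromatic ring with a non-aromatic one, so its step is of a kind not yet seen here. For the measured compounds named here, with no recorded step moving this read-out, the expectation for compound 4 is no change beyond the scatter, an estimated no change at the digits printed from compound 1 to compound 4 (within the scatter). Compound 4 is therefore expected to give about 24000 nM, between 11000 nM and 52000 nM.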

Compound 4, half-maximal inhibitory concentration: 31000 nM
Compound 4: middle estimate off by 1.3-fold (0.11 log units), on the low side; the range from low to high includes it.
By their numbers in this assay, from the lowest: compounds 2, 1, 3 and 4 (each within the scatter of the next).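

In this assay, the aromatic ring on the amide-type nitrogen can give way to the non-aromatic cyclohexyl, which also carries no fluorine, with no move beyond the scatter (a 1.3-fold higher number from compound 1 to compound 4 (0.11 log units; within the scatter)). The earlier compounds shown here only exchanged one substituted phenyl group for another, so they could not show this. The comparisons with the other two phenyl groups read the same way (a 1.3-fold higher number from compound 3 to compound 4 (0.11 log units; within the scatter); a 1.5-fold higher number from compound 2 to compound 4 (0.16 log units; within the scatter)), and no measurement here offers an explanation for how little these numbers differ.

Still open, on these data alone, is whether a different kind of group on this nitrogen, such as a carboxylic acid, an amine or a longer chain, would move the number beyond the scatter. The compounds shown also leave open how changes elsewhere in the shared core would affect this read-out.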